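The source may report more compounds than this note shows. Statements on the series, on what has been measured and on what is new or still open speak of the compounds shown alone.

Compound 2 `c1cnc(-c2ccccc2OCC2=NCCN2)nc1` stands among three analogues examined in a functional assay for activation of Alpha-1B adrenergic receptor (Homo sapiens), read by calcium flux; on this read-out lower numbers stand for an effect already at smaller amounts and higher numbers for an effect only at larger amounts of compound. In this assay compound 2 gives only a limit, < 100000 nM. Compound 1 `Cc1cccc(-c2ccccc2OCC2=NCCN2)n1` likewise gives only a limit in this assay, < 100000 nM. Compound 3 `c1c[nH]c(-c2ccccc2OCC2=NCCN2)c1` gives 1 nM in this assay. The step that the limit leaves unreadable from compound 2 to compound 3 cannot be sized since the limit of < 100000 nM in this assay, at which 2 of the 3 values shown sit, is where compound 2 sits. Compound 4 `c1ccc(-c2ccsc2)c(OCC2=NCCN2)c1` differs from compound 2 by thiophen-3-yl in place of pyrimidin-2-yl on an aromatic carbon. Among the compounds with values here, the only measured step that bears on this change, a step that the limit leaves unreadable from compound 2 to compound 3, also exchanges the pyrimidin-2-yl for a five-membered aromatic ring, so a downward step in this assay is expected for compound 4, of a size that cannot be read from compound 2. Compound 4 is estimated at 30 nM, within 3 nM to 300 nM. The step that the limit leaves unreadable from compound 2 to compound 4 is thus expected.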

Compound 4, half-maximal effective concentration: 15.9 nM
Estimate against measurement, compound 4: 1.9-fold (0.28 log units) above; the measured number falls inside the stated range.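

In this assay, a second five-membered aromatic ring on this aromatic carbon also gives a numerical value, so such a value is not confined to 1H-pyrrol-2-yl. The two rings are not interchangeable, however: thiophen-3-yl in place of 1H-pyrrol-2-yl gives a 16-fold higher number from compound 3 to compound 4 (1.20 log units; beyond the scatter). The steps out of compound 2 cannot be read, since compound 2 stands only at a limit: the limit of < 100000 nM in this assay, at which 2 of the 4 values shown sit.

As far as these compounds go, it remains open whether the hetero atom or the point of attachment accounts for the step between the two five-membered rings. From the compounds shown here alone, how an amine or a carboxylic acid on this aromatic carbon would read out also stays open.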